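A few compounds are considered here, and "the series" means these few. Any claim that something is new, unique, unknown or untested is made for them only; others in the source may bear on it.

Measured compounds:
- compound 1 `O=C(O)c1csc(-n2nc(-c3cccc(F)c3)c3ccccc32)n1`, 20 nM
- compound 2 `O=C(O)c1csc(-n2nc(-c3ccc(Cl)cc3)c3ccccc32)n1`, 12 nM
- compound 3 `O=C(O)c1csc(-n2nc(-c3ccc(C(F)(F)F)cc3)c3ccccc32)n1`, 140 nM

In an assay on isolated protein for antagonist activity at prostaglandin E2 receptor EP1 subtype (Homo sapiens), read by reporter gene assay (on this read-out higher numbers stand for weaker inhibition and lower numbers for stronger inhibition), compound 2 gives the lowest number of the three. Compound 1 is nearest, with a 1.7-fold lower number from compound 1 to compound 2 (0.22 log units; within the scatter), so compound 1 and compound 2 cannot be ordered. Compound 3 is furthest, with a 12-fold higher number from compound 2 to compound 3 (1.07 log units; beyond the scatter).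

Compound 4 `O=C(O)c1csc(-n2nc(C3=CCCCC3)c3ccccc32)n1` is not yet measured. It differs from compound 2 in one place: cyclohex-1-en-1-yl in place of 4-chlorophenyl on an aromatic carbon. Neither measured step exchanges the ring itself for a non-aromatic one; both keep a phenyl and only alter its substituent. The step to compound 3 shows that a change at this position can move this assay by a large amount, while the step from compound 1 to compound 2 shows a change that stays within the scatter. Among the compounds with values here, with no direct precedent, a modest upward move is expected: a 3.8-fold higher number from compound 2 to compound 4 (0.57 log units; beyond the scatter), with a wide range. For compound 4 the expected value is 45 nM, between 12 nM and 200 nM.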

Compound 4, half-maximal inhibitory concentration: 4 nM
Compound 4: middle estimate off by 11-fold (1.05 log units), on the high side, and the stated range ends above it.
By their numbers in this assay, from the lowest: compound 4; then compounds 2 and 1 (each within the scatter of the next); then compound 3.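

In this assay the carbon that carries the phenyl groups of compounds 1 to 3 also accepts a non-aromatic ring: cyclohex-1-en-1-yl gives a 3.0-fold lower number from compound 2 to compound 4 (0.48 log units; beyond the scatter) and a 5.0-fold lower number from compound 1 to compound 4 (0.70 log units; beyond the scatter) without any change to the rest of the molecule. Among the four compounds, a six-membered aromatic ring of carbon only is therefore not required at this position for a low number, and the lowest value comes with no chloro, fluoro or trifluoromethyl substituent on the ring. Nothing available bears on what lies behind these steps.

From the compounds shown here alone, it remains open whether the ring's double bond matters, which a fully saturated cyclohexyl group would test. Also open, going by these compounds, is how this ring responds to substituents such as a hydroxyl or an amine, and whether a smaller cyclopentenyl ring fits equally well.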